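The compounds below may be only part of what the source reports. "The series", "measured", "known", "first", "only" and "open" are said of these compounds alone.

Series notes. Compound 1 `O=C1C=C(Cl)C(O)(c2ccccc2)N1C1CCCC1` is the reference member; in an assay on cell membranes for displacement of a labelled ligand from Cholecystokinin receptor type A (Rattus norvegicus), read by CCK-8 assay, with a stated time of 2 h (a lower number here means a stronger inhibitor, a higher number a weaker inhibitor), compound 1 gives 360 nM. Compound 2 `O=C1C=C(Cl)C(O)(c2ccc(Cl)cc2)N1C1CCCC1` carries the change chloro in place of hydrogen on an aromatic carbon and in this assay compound 2 gives 2500 nM, a step of a 6.9-fold higher number from compound 1 to compound 2 (0.84 log units; beyond the scatter). Compound 3 `CCCCCCN1C(=O)C=C(Cl)C1(O)c1ccccc1` differs from compound 1 by hexyl in place of cyclopentyl on an amide-type nitrogen in a ring; in this assay compound 3 gives 4500 nM, a step of a 13-fold higher number from compound 1 to compound 3 (1.10 log units; beyond the scatter). Compound 2 and compound 3 sit within the scatter of each other, so no order between them is read. Compound 4 `CCCCCCN1C(=O)C=C(Cl)C1(O)c1ccc(Cl)cc1` has not yet been measured in this assay. It differs from compound 3 by chloro in place of hydrogen on an aromatic carbon, the same change at the same place as from compound 1 to compound 2, where it made a 6.9-fold higher number from compound 1 to compound 2 (0.84 log units; beyond the scatter). The two cores differ as described under (hexyl in place of cyclopentyl on an amide-type nitrogen in a ring). Among the compounds with values here, that single earlier instance is the only guide; whether the core bearing hexyl responds alike is untested. In this assay the expected step is a 6.7-fold higher number from compound 3 to compound 4 (0.82 log units; beyond the scatter), because the same change gave a 6.9-fold higher number from compound 1 to compound 2 (0.84 log units; beyond the scatter). For compound 4 the estimate in this assay is 30000 nM, from 10000 nM to 100000 nM.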

Compound 4, half-maximal inhibitory concentration: 3600 nM
For compound 4 the middle estimate is 8.3-fold (0.92 log units) above the measured one, and the stated range ends above it.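

In this assay, the change from phenyl to 4-chlorophenyl does not carry over from the core bearing cyclopentyl to the core bearing hexyl: there it gives a 1.3-fold lower number from compound 3 to compound 4 (0.10 log units; within the scatter), and the two instances of the change disagree: the same change on two cores in this assay, a 6.9-fold higher number (0.84 log units; beyond the scatter) from compound 1 to compound 2 and a 1.3-fold lower number (0.10 log units; within the scatter) from compound 3 to compound 4, 8.7-fold (0.94 log units) apart, beyond the scatter of two such steps Read the other way, hexyl in place of cyclopentyl does not carry over between the phenyl and 4-chlorophenyl compounds either, giving a 1.4-fold higher number from compound 2 to compound 4 (0.16 log units; within the scatter), and its two instances also disagree: the same change on two cores in this assay, a 13-fold higher number (1.10 log units; beyond the scatter) from compound 1 to compound 3 and a 1.4-fold higher number (0.16 log units; within the scatter) from compound 2 to compound 4, 8.7-fold (0.94 log units) apart, beyond the scatter of two such steps Both comparisons come from the same four compounds, so they show that the two changes are not additive in this set, but they do not show the reason or how any other pair of groups would behave.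

On these data alone, it remains open whether the chloro step on a core bearing another nitrogen group, such as butyl or cyclohexyl, would resemble the step on the core of compound 1 or that on the core of compound 3. As far as these compounds go, it is also open whether fluoro or methoxy in the same place would follow the pattern seen with chloro.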